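A few compounds are considered here, and "the series" means these few. Any claim that something is new, unique, unknown or untested is made for them only; others in the source may bear on it.

Working notes on the series.

Compound 3 `CCCC[C@@](C)(OC)[C@H](O)/C=C/C1[C@H](O)CC(=O)[C@@H]1C/C=C\CCCC(=O)OC` gives 0.757 mg/kg in a functional assay on the whole organism with Mus musculus as the target; a higher number here means that more compound is needed for the effect, a lower number that less compound is needed. Going by the values given here, of the two numbers so far, that is the lower one, though compound 1 `CCCC[C@](C)(OC)[C@@H](O)/C=C/C1[C@H](O)CC(=O)[C@@H]1C/C=C\CCCC(=O)OC` stands close: in this assay compound 1 gives 0.912 mg/kg, and the step of a 1.2-fold lower number from compound 1 to compound 3 (0.08 log units; within the scatter) is within the scatter. Compound 2 `CCCC[C@@](C)(OC)[C@@H](O)/C=C/C1[C@H](O)CC(=O)[C@@H]1CCCCCCC(=O)OC` has the saturated chain, and in this assay compound 2 reaches only a limit, > 4 mg/kg; that is all the assay reports for it, as noted under (the limit of > 4 mg/kg in this assay, at which 1 of the 3 values shown sits).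

The next compound, compound 4 `CCCC[C@@](C)(OC)[C@H](O)/C=C/C1[C@H](O)CC(=O)[C@@H]1CCCCCCC(=O)OC`, differs from compound 3 in one place: 5-(methoxycarbonyl)pentyl in place of 5-(methoxycarbonyl)pent-1-en-1-yl on a saturated chain carbon bound to a saturated ring carbon.

Among the compounds with values here, no measured step covers exactly this change from a measured neighbour. Within the data shown here, the only measured step, that from compound 1 to compound 3, concerns configuration alone and is within the scatter. The pair of compound 1 and compound 2 shows a number on one side and a limit on the other, with the limit at the saturated chain. On that basis the change is expected to raise the number for compound 4 by about a 6.6-fold higher number from compound 3 to compound 4 (0.82 log units; beyond the scatter), and the estimate for compound 4 in this assay is 5 mg/kg, with a range from 1.5 mg/kg to 20 mg/kg, a limit rather than a number being the likelier outcome.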

Compound 4, dose for half-maximal effect: 1.35 mg/kg
For compound 4 the middle estimate is 3.7-fold (0.57 log units) above the measured one; the measured number lies below the stated range.
By their numbers in this assay, from the lowest: compounds 3, 1 and 4 (each within the scatter of the next). At a limit, above all of these: compound 2.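

In this assay, the step of a 1.8-fold higher number from compound 3 to compound 4 (0.25 log units; within the scatter) shows that, in the configuration of compound 3, 5-(methoxycarbonyl)pentyl in place of 5-(methoxycarbonyl)pent-1-en-1-yl on a saturated chain carbon bound to a saturated ring carbon stays within the scatter. The saturated chain alone therefore does not carry compound 4 to a limit, and with that chain the stereocentre at a saturated chain carbon comes with a step beyond the scatter, an at least 2.9-fold lower number from compound 2 to compound 4 (0.47 log units; beyond the scatter). Compound 2 gives only a limit, > 4 mg/kg, and the reading of this step carries a caveat: the fact that one of compounds 2 and 4 is drawn with a defined configuration and the other without, at the place where they differ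

The compounds shown leave open what number compound 2 would give in place of its limit. They also leave open how a carboxylic acid in place of the methoxycarbonyl group, or a longer chain, would read in this assay.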